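Bromo for methoxy on a shared core: a second test

This account rests on a few compounds, and the source may have more. Where it says the series, first, only, none or still open, it means among the compounds named here.

Compound 1 `COc1ccc(-c2ccnc(Nc3ccc([N+](=O)[O-])cc3)n2)cc1` gives 537 nM in an assay on isolated protein for inhibition of phosphatidylinositol 4,5-bisphosphate 3-kinase catalytic subunit beta isoform (Homo sapiens); on this read-out lower numbers stand for stronger inhibition and higher numbers for weaker inhibition. Among the compounds with values here, compound 2 `O=[N+]([O-])c1ccc(Nc2nccc(-c3ccc(Br)cc3)n2)cc1` carries the change bromo in place of methoxy on an aromatic carbon and gives 961 nM in this assay; the step of a 1.8-fold higher number from compound 1 to compound 2 (0.25 log units; within the scatter) is the only measured instance of this change so far. Compound 3 `COc1ccc(-c2ccnc(Nc3cccc(OC)c3)n2)cc1` gives 729 nM in this assay; it differs from compound 1 in more than one place, and the difference between the two cores is not broken down here. Compound 4 `COc1cccc(Nc2nccc(-c3ccc(Br)cc3)n2)c1` has not yet been measured; it differs from compound 3 by bromo in place of methoxy on an aromatic carbon, the same change as from compound 1 to compound 2, in the same surroundings. Within the data shown here, for compound 4 a step of a 1.6-fold higher number from compound 3 to compound 4 (0.22 log units; within the scatter) is expected in this assay, because a 1.8-fold higher number from compound 1 to compound 2 (0.25 log units; within the scatter) is the one earlier reading of this change on the shared core, and its size lies within the scatter, so the expectation is loose. Compound 4 is therefore estimated at 1200 nM in this assay, with a range from 500 nM to 3000 nM.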

Compound 4, half-maximal inhibitory concentration: 977 nM
Estimate against measurement, compound 4: 1.2-fold (0.09 log units) above, within the range that was stated.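

In this assay, bromo in place of methoxy on an aromatic carbon gives a 1.3-fold higher number from compound 3 to compound 4 (0.13 log units; within the scatter), and this second reading can be set beside the first: the same change on two cores in this assay, a 1.8-fold higher number (0.25 log units; within the scatter) from compound 1 to compound 2 and a 1.3-fold higher number (0.13 log units; within the scatter) from compound 3 to compound 4, 1.3-fold (0.13 log units) apart, within the scatter of two such steps. Within the data shown here, the change therefore reads the same on the core of compound 1 and on the core of compound 3, as far as these two pairs can tell, and the difference between the cores leaves no mark on the step that can be told from ordinary repeat variation. This does not show that bromo and methoxy truly differ in this assay, as each step lies within the scatter on its own, and two pairs cannot establish that the change would carry to cores beyond these.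

The compounds shown leave open what an amine, a carboxylic acid or a longer alkoxy chain would give in the place of the methoxy or bromo group. Also open, from the compounds shown here alone, is how the same change would read on a core carrying an amine in place of the nitro group of compound 1.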